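This account rests on a few compounds, and the source may have more. Where it says the series, first, only, none or still open, it means among the compounds named here.

This set comes from a small series built on a fused two-ring core carrying a benzyl-type amine and a second substituent on the same ring. Among the compounds with values here, compound 1 `CSc1ccc(CNc2nc(SC)nc3ncccc23)cc1` is the one measured compound that carries a methylsulfanyl group there; in an ADME assay on 184B5 cells (Homo sapiens) for cytotoxicity, read by MTT assay, with a stated time of 72 h (on this read-out higher numbers stand for weaker inhibition of growth and lower numbers for stronger inhibition of growth), compound 1 gives 1140 nM. Compound 3 `[SeH]c1nc([SeH])c2ccccc2n1` carries a selenium atom at both positions and no amine; in this assay compound 3 gives 2500 nM. Compound 2 `COc1ccc(CNc2nc([SeH])nc3ccccc23)cc1` pairs the amine with a single selenium atom. Within the data shown here, for compound 2 this assay returns only a limit, > 100000 nM, so no number is known for it, and it is the one value that sits at the limit of > 100000 nM in this assay, at which 1 of the 3 values shown sits.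

Compound 4 `COc1ccc(CNc2nc(SC)nc3ccccc23)cc1` is the methylsulfanyl counterpart of compound 2 on the same core. The change from compound 2 to compound 4 is a group of 2 heavy atoms (1 carbon, 1 sulfur; no ring) in place of one selenium atom, on an aromatic carbon. Among the measured compounds shown here, no measured pair in this set isolates that exchange, so no step of known size can be quoted. Starting from a limit, the step from compound 2 to compound 4 is expected to be an at least 25-fold lower number from compound 2 to compound 4 (1.39 log units; beyond the scatter), a move toward stronger inhibition of growth. Compound 4 is therefore estimated at 4000 nM, with a plausible range from 800 nM to 30000 nM.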

Compound 4, concentration for total growth inhibition: > 100000 nM
Compound 4 ended at the assay's limit; the forecaster's own chance of this, stated with the estimate: 25%; at least 25-fold (1.39 log units) between middle value and limit.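

Compound 2 and compound 4 each return only a limit and not a number, so no step between them can be read, because both values stand at the same end of the scale: the limit of > 100000 nM in this assay, at which 2 of the 4 values shown sit.

The compounds shown leave open how far placing methylsulfanyl instead of the selenium atom on the shared core shifts the result in this assay.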